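Cyclohexyl replaces an amino chain: a cell tolerance estimate

The source may report more compounds than this note shows. Statements on the series, on what has been measured and on what is new or still open speak of the compounds shown alone.

Measured in an ADME assay on MDBK cells (Bos taurus) for cytotoxicity; a lower number here means that less compound is tolerated, a higher number that more compound is tolerated:
- compound 1 `Brc1ccc(Cn2ccc3nc(-c4ccccc4)nc-3c2)cc1`: 83000 nM
- compound 2 `CC(C)N(CCn1ccc2nc(-c3ccccc3)nc-2c1)C(C)C`: > 100000 nM

Compound 2 gives > 100000 nM, which is a limit of the assay and not a number. It stands at the limit of > 100000 nM in this assay, at which 1 of the 2 values shown sits.

Compound 3 `c1ccc(-c2nc3ccn(CC4CCCCC4)cc-3n2)cc1` differs from compound 2 in one place, with cyclohexyl in place of (diisopropylamino)methyl on a saturated chain carbon bound to an aromatic nitrogen.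

Within the data shown here, one measured step touches the same place: an at least 1.2-fold higher number from compound 1 to compound 2 (0.08 log units; that floor lies within the scatter). That step is small and rests on a limit, so it sets no firm size. Compound 3 regains a ring at this place, as compound 1 has with its 4-bromophenyl at 83000 nM. No step beyond the scatter is therefore expected in this assay, and the estimate is an at least 1.2-fold lower number from compound 2 to compound 3 (0.09 log units; that floor lies within the scatter). For compound 3 the expected value is 80000 nM, with an estimated range from 35000 nM to 100000 nM.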

Compound 3, half-maximal cytotoxic concentration: > 100000 nM
Compound 3: a limit, no number; the forecaster's own chance of this, stated with the estimate: 40%; middle value at least 1.2-fold (0.09 log units) from the limit.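

In this assay compound 3 gives > 100000 nM, which is a limit of the assay and not a number. The step between compound 2 and compound 3 cannot be read, because both values are limits: the limit of > 100000 nM in this assay, at which 2 of the 3 values shown sit.

Even so, the limit is reached at this place both with the (diisopropylamino)methyl of compound 2, which carries a nitrogen, and with the cyclohexyl of compound 3, which is carbon only, while replacing 4-bromophenyl with cyclohexyl gives an at least 1.2-fold higher number from compound 1 to compound 3 (0.08 log units; that floor lies within the scatter).

From the compounds shown here alone, how far compound 2 and compound 3 lie past the limit stays unknown, so they cannot be ranked against each other. Going by these compounds, whether a carboxylic acid or a longer chain at this place would bring the number in this assay down to a measurable value also stays open.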